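Swapping a Thiophene for a Methoxyphenyl on a Shared Core

The source may report more compounds than this note shows. Statements on the series, on what has been measured and on what is new or still open speak of the compounds shown alone.

Of the compounds shown here, two on a shared core have been measured. Compound 1 `COc1ccc(-c2cn3ccnc3c(-c3ccc4ncn(C5CCCCC5)c4c3)n2)cc1` carries a 4-methoxyphenyl group; in a functional assay on NCI-H23 cells (Homo sapiens) for inhibition, read by sulforhodamine B assay, with a stated time of 48 h, tested at 10 uM (on this read-out higher numbers stand for more inhibition at the one concentration tested (going by the name of the read-out) and lower numbers for less inhibition), compound 1 gives 62.2%. Compound 2 `c1cn2cc(-c3ccsc3)nc(-c3ccc4ncn(C5CCCCC5)c4c3)c2n1` carries a thiophen-3-yl group on the same aromatic carbon; in this assay compound 2 gives 10%. That step was a number 52.2 percentage points lower from compound 1 to compound 2 (beyond the scatter), so compound 2 stands lowest of the two numbers, with compound 1 as its nearest neighbour well beyond the scatter above it.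

Compound 3 `COc1ccccc1-c1cn2ccnc2c(-c2ccc3ncn(C4CCCCC4)c3c2)n1` differs from compound 2 in one place: 2-methoxyphenyl in place of thiophen-3-yl on an aromatic carbon. For the measured compounds named here, the only measured step that bears on this change is the one from compound 1 to compound 2, which showed how strongly this one place on the shared core moves the read-out. As compound 3 brings back a methoxyphenyl, though as 2-methoxyphenyl rather than 4-methoxyphenyl, an upward step is expected, its size uncertain. Compound 3 is expected to reach 40% in this assay, with a range from 10% to 70%. This corresponds to an expected step of a number 30 percentage points higher from compound 2 to compound 3 (beyond the scatter).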

Compound 3, a percentage reported as inhibition, at one concentration (the size of the read-out at that concentration, not a potency): 2.79%
Compound 3: middle estimate off by 37.2 percentage points, on the high side; the whole stated range lies above it.
By their numbers in this assay, from the lowest: compounds 3 and 2 (each within the scatter of the next); then compound 1.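

In this assay, bringing a methoxyphenyl group back to this aromatic carbon did not bring the read-out back: 2-methoxyphenyl in place of thiophen-3-yl gave a number 7.2 percentage points lower from compound 2 to compound 3 (within the scatter), so these two groups cannot be told apart here, although they differ in ring size and in heavy-atom count. The comparison between the two methoxyphenyl groups adds what the first pair could not show, since 2-methoxyphenyl in place of 4-methoxyphenyl gave a number 59.4 percentage points lower from compound 1 to compound 3 (beyond the scatter), which means that having a methoxyphenyl group at this place is not enough on its own and that, among the three compounds, only compound 1 stands apart from the others. Nothing at hand accounts for this large gap between the two methoxyphenyl groups.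

The compounds shown leave open whether the higher read-out depends on the methoxy group itself or on any substituent at the 4-position of the phenyl ring, a question that 4-hydroxyphenyl, 4-fluorophenyl, unsubstituted phenyl or 3-methoxyphenyl at this place would bear on. They also leave open how the three compounds would rank at other concentrations, as each was read at a single one.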